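Isopentyl in place of 1,1-dimethylpropyl: expectation for compound 4

This account rests on a few compounds, and the source may have more. Where it says the series, first, only, none or still open, it means among the compounds named here.

In a functional assay (aorta) with Rattus norvegicus as the target (a higher number here means a weaker inhibitor, a lower number a stronger inhibitor), compound 1 (`CC(/N=C(\NC#N)Nc1cc(C(F)(F)F)cc(C(F)(F)F)c1)C(C)(C)C`) gives 8700 nM and compound 2 (`CC(C)CC/N=C(\NC#N)Nc1cc(C(F)(F)F)cc(C(F)(F)F)c1`) gives 5600 nM in the same test. Compound 3 (`CCC(C)(C)/N=C(\NC#N)Nc1cc(Cl)cc(Cl)c1`) gives 300 nM as the lowest number of the three, and its gap to each of the others lies beyond the scatter.

Compound 4 (`CC(C)CC/N=C(\NC#N)Nc1cc(Cl)cc(Cl)c1`) carries isopentyl in place of 1,1-dimethylpropyl on a double-bonded nitrogen. The two have the same atoms, joined differently.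

Within the data shown here, the one measured step that bears on this change is a 1.6-fold lower number from compound 1 to compound 2 (0.19 log units; within the scatter) and it stays within the scatter. That step also puts isopentyl on a double-bonded nitrogen, but isopentyl replaces 1,2,2-trimethylpropyl there rather than 1,1-dimethylpropyl. It also sits on the core of compound 1, which differs from the core of compound 3. Among the measured compounds shown here, no measured pair shows 1,1-dimethylpropyl leaving directly, so the transfer is loose and the range is kept wide.

For the measured compounds named here, with a 1.6-fold lower number from compound 1 to compound 2 (0.19 log units; within the scatter) as the only guide, no step beyond the scatter is expected in this assay and the estimated step is no change at the digits printed from compound 3 to compound 4 (within the scatter) for this change. Compound 4 is expected at 300 nM within an estimated range of 90 nM to 1000 nM as a working figure.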

Compound 4, half-maximal inhibitory concentration: 18700 nM
For compound 4 the middle estimate is 62-fold (1.79 log units) below the measured one; the whole stated range lies below it.
By their numbers in this assay, from the lowest: compound 3; then compounds 2 and 1 (each within the scatter of the next); then compound 4.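

In this assay, isopentyl in place of 1,1-dimethylpropyl on a double-bonded nitrogen gives a 62-fold higher number from compound 3 to compound 4 (1.79 log units; beyond the scatter), even though the two groups have the same heavy-atom count and all five are carbon. At this position on the core of compound 3, the way those carbons are joined therefore matters to the read-out, whereas a 1.6-fold lower number from compound 1 to compound 2 (0.19 log units; within the scatter) showed no step beyond the scatter when isopentyl replaced 1,2,2-trimethylpropyl on the core of compound 1. No measurement available here accounts for the size of the new step.

On these data alone, it remains open whether this step belongs to the departure of 1,1-dimethylpropyl specifically or depends on the core of compound 3, a question that a pair carrying 1,1-dimethylpropyl on the core of compound 1 would address. Also open, as far as these compounds go, is where a tert-butyl group, a longer chain such as n-hexyl, or a chain ending in an amine would fall in this assay relative to compound 3 at 300 nM and compound 4 at 18700 nM.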